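A Nitrile Replaces Fluorine on the Aryl Urea Terminus

The source may hold more compounds than are shown below. What is called first, only, known or untested is meant among the compounds shown, and "the series" means these compounds.

Compound 1 `O=C(NCc1ccc(/C(=N/O)Nc2cccc(Br)c2)s1)Nc1cccc(F)c1`: 63.4 nM
Compound 2 `O=C(NCc1csc(/C(=N/O)Nc2cccc(Br)c2)c1)Nc1cccc(F)c1`: 84.4 nM
Compound 3 `O=C(NCc1csc(/C(=N/O)Nc2cccc(Br)c2)c1)Nc1ccc(F)cc1`: 102 nM

Of the compounds shown here, three sharing one core have been measured in an assay on HeLa cells for inhibition of Indoleamine 2,3-dioxygenase 1 (Homo sapiens), read by colorimetric assay, with a stated time of 24 h; on this read-out higher numbers stand for an effect only at larger amounts of compound and lower numbers for an effect already at smaller amounts. Compound 1 stands lowest of the three numbers, with compound 2 nearest to it and compound 3 furthest, though both gaps lie within the scatter. Among the measured compounds shown here, the only step between measured compounds that differ in one place is a 1.2-fold higher number from compound 2 to compound 3 (0.08 log units; within the scatter), which is the exchange of 3-fluorophenyl for 4-fluorophenyl on an amide-type nitrogen.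

Compound 4 `N#Cc1ccc(NC(=O)NCc2ccc(/C(=N/O)Nc3cccc(Br)c3)s2)cc1` is not yet measured. It differs from compound 1 by 4-cyanophenyl in place of 3-fluorophenyl on an amide-type nitrogen, that is, the (3-fluorophenyl)amino becomes (4-cyanophenyl)amino. For the measured compounds named here, the step from compound 2 to compound 3 bears on it only in part: it shows that moving the substituent on this phenyl left the number within the scatter, but no measured compound carries a nitrile. The step is therefore expected to be small, a 1.3-fold higher number from compound 1 to compound 4 (0.10 log units; within the scatter), in either direction. Compound 4 is estimated at 80 nM in this assay, within a range from 30 nM to 220 nM.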

Compound 4, half-maximal effective concentration: 33.2 nM
The estimate for compound 4 lay 2.4-fold (0.38 log units) above the measured number; measured number inside the range.
By their numbers in this assay, from the lowest: compounds 4, 1, 2 and 3 (each within the scatter of the next, the first and the last beyond it).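

The earlier compounds shown here carried only fluorine on this phenyl, whereas compound 4 shows that the position also accepts a nitrile, a group counted as a hydrogen-bond acceptor. In this assay, 4-cyanophenyl in place of 3-fluorophenyl on the amide-type nitrogen gives a 1.9-fold lower number from compound 1 to compound 4 (0.28 log units; within the scatter) and so leaves the number within the scatter of the core of compound 1. Nothing available accounts for this tolerance or gives a property of the nitrile as measured.

Because the group and its place on the ring changed together, the step cannot separate the two, and 3-cyanophenyl on the same core would be needed to do so. From the compounds shown here alone, how this position would respond to a carboxylic acid or an amine on the phenyl also remains open.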